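A few compounds are considered here, and "the series" means these few. Any claim that something is new, unique, unknown or untested is made for them only; others in the source may bear on it.

For the measured compounds named here, compound 2 `CC(C)N1CCN(c2nc(Nc3ccc(C(F)(F)F)cc3)c3nc(Nc4c(Cl)cccc4Cl)sc3n2)CC1` is the one compound here with a number rather than a limit: in a functional assay on HEK293 cells for antagonist activity at transient receptor potential cation channel subfamily V member 1 (Rattus norvegicus), read by calcium flux (on this read-out lower numbers stand for stronger inhibition and higher numbers for weaker inhibition), compound 2 gives 119 nM. Compound 1 `FC(F)(F)c1ccc(Nc2nc(N3CCNCC3)nc3sc(Nc4c(Cl)cccc4Cl)nc23)cc1` reaches only a limit of the assay; in this assay compound 1 gives > 5000 nM. Going by the values given here, the single measured step, an at least 42-fold lower number from compound 1 to compound 2 (1.62 log units; beyond the scatter), rests on that limit (the limit of > 5000 nM in this assay, at which 1 of the 2 values shown sits), so its true size is known only as large. Compound 3 `CN(C)c1nc(Nc2ccc(C(F)(F)F)cc2)c2nc(Nc3c(Cl)cccc3Cl)sc2n1` differs from compound 2 by dimethylamino in place of 4-isopropylpiperazin-1-yl on an aromatic carbon. The measured step bears on this change only loosely: it shows that the group at this part of the shared core can shift the number strongly, and that the isopropyl group on the ring amine of compound 2 matters. Removing that ring together with its isopropyl group is expected to move the number upward, toward weaker inhibition, by roughly a 13-fold higher number from compound 2 to compound 3 (1.10 log units; beyond the scatter). Compound 3 is therefore estimated at 1500 nM, within 300 nM to 8000 nM.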

Compound 3, half-maximal inhibitory concentration: 43 nM
Estimate against measurement, compound 3: 35-fold (1.54 log units) above; the measured number lies below the stated range.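

In this assay, a piperazine ring at this position of the shared core proves unnecessary: dimethylamino in place of 4-isopropylpiperazin-1-yl gives a 2.8-fold lower number from compound 2 to compound 3 (0.44 log units; beyond the scatter). The gap to the group with the free ring amine is far wider, an at least 110-fold lower number from compound 1 to compound 3 (2.06 log units; beyond the scatter), but this size is only a bound, since the value of compound 1 is a limit of the assay: the limit of > 5000 nM in this assay, at which 1 of the 3 values shown sits. Of the three groups shown, the one without a ring therefore gives the lowest number and piperazin-1-yl the highest, so a small open-chain amine can serve here at least as well as the isopropyl-capped ring.

As far as these compounds go, whether the gain comes from losing the ring or from the smaller group stays open. A pyrrolidine, a morpholine or a diethylamino group at this place could help separate those two readings.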